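The compounds below may be only part of what the source reports. "The series", "measured", "known", "first", "only" and "open" are said of these compounds alone.

Three compounds share one core and differ only in the tail carried on the carbamate nitrogen. Compound 1 `CC(C)(N)C(=O)N[C@H](COCc1ccccc1)c1nnnn1CCOC(=O)NCCO` carries a (2-hydroxyethyl)amino group there, and in a functional assay on H4 cells with growth hormone secretagogue receptor type 1 (Homo sapiens) as the target, read by FLIPR (a higher number here means that more compound is needed for the effect, a lower number that less compound is needed), compound 1 gives 3 nM. Compound 2 `CC(C)(N)C(=O)N[C@H](COCc1ccccc1)c1nnnn1CCOC(=O)NCCCO` carries a (3-hydroxypropyl)amino group; in this assay compound 2 gives 5.5 nM. Compound 3 `CN(CCCCO)C(=O)OCCn1nnnc1[C@@H](COCc1ccccc1)NC(=O)C(C)(C)N` carries a (4-hydroxybutyl)(methyl)amino group; in this assay compound 3 gives 3.8 nM. Compound 1 stands at the low end of these three numbers, but every comparison falls within the scatter: a 1.8-fold higher number from compound 1 to compound 2 (0.26 log units; within the scatter), a 1.3-fold higher number from compound 1 to compound 3 (0.10 log units; within the scatter) and a 1.4-fold lower number from compound 2 to compound 3 (0.16 log units; within the scatter). The tail on this nitrogen has so far left the result essentially unchanged.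

Compound 4 `CC(C)(N)C(=O)N[C@H](COCc1ccccc1)c1nnnn1CCOC(=O)NC[C@H]1CCCO1` is the next variation at the same place: oxolan-2-yl in place of hydroxymethyl on a saturated chain carbon bound to an amide-type nitrogen. The hydrogen-bond donor present in compounds 1, 2 and 3 is absent in compound 4. Among the compounds with values here, the measured steps lengthened the tail and added a methyl group on the nitrogen without any step beyond the scatter; a ring in place of the open chain is a larger change, yet nothing among the measured compounds points in a direction. Compound 4 is therefore expected to give about 4 nM in this assay, between 1.5 nM and 11 nM, an expected step of a 1.3-fold higher number from compound 1 to compound 4 (0.12 log units; within the scatter).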

Compound 4, half-maximal effective concentration: 9.5 nM
Beside the measured number, compound 4's estimate is 2.4-fold (0.38 log units) below it, within the range that was stated.
By their numbers in this assay, from the lowest: compounds 1, 3, 2 and 4 (each within the scatter of the next, the first and the last beyond it).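

Swapping the open chain for the oxolan-2-yl ring produces the first steps at this position that go beyond the scatter in this assay: a 3.2-fold higher number from compound 1 to compound 4 (0.50 log units; beyond the scatter), and a 2.5-fold higher number from compound 3 to compound 4 (0.40 log units; beyond the scatter), both of them modest. The effect is not clear-cut, however, since the comparison with the third open-chain tail stays inside the scatter, a 1.7-fold higher number from compound 2 to compound 4 (0.24 log units; within the scatter), so the ring separates compound 4 from only two of the three earlier compounds. The change removes a hydroxymethyl group carrying a hydrogen-bond donor and brings in a ring with no donor and a defined stereocentre, all in one move, and nothing shown here tells which of these features matters.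

The compounds shown leave open whether the loss of the donor or the presence of the ring counts more, a question that an open-chain 2-methoxyethyl tail or a 4-hydroxycyclohexyl group could help to separate. Also open, on these data alone, are the opposite stereoisomer of the oxolan-2-yl group and tails ending in an amine or a carboxylic acid.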